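Methoxy in place of (ethylcarbamoyl)amino on the shared core

A few compounds are considered here, and "the series" means these few. Any claim that something is new, unique, unknown or untested is made for them only; others in the source may bear on it.

In a functional assay for inhibition (on this read-out lower numbers stand for stronger inhibition and higher numbers for weaker inhibition), compound 1 `O=[N+]([O-])c1ccc(S(=O)(=O)Nc2cc(F)c(O)c(F)c2)cc1` gives 45700 nM. Within the data shown here, on the same read-out compound 2 `CCNC(=O)Nc1ccc(S(=O)(=O)Nc2cc(F)c(O)c(F)c2)cc1` gives 81700 nM, so the two numbers lie within the scatter of each other, and compound 1 is the only neighbour of compound 2 so far.

The next structure is compound 3 `COc1ccc(S(=O)(=O)Nc2cc(F)c(O)c(F)c2)cc1`, with methoxy in place of (ethylcarbamoyl)amino on an aromatic carbon, para to a large group: methoxy in place of (ethylcarbamoyl)amino on an aromatic carbon.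

Among the measured compounds shown here, one measured step bears on this change, at the same carbon: a 1.8-fold higher number from compound 1 to compound 2 (0.25 log units; within the scatter), with (ethylcarbamoyl)amino in place of nitro. That single step stays within the scatter, so no step beyond the scatter is expected in this assay.

The expected step is a 1.4-fold lower number from compound 2 to compound 3 (0.13 log units; within the scatter). For compound 3 the estimated value is 60000 nM, with an expected range of 20000 nM to 150000 nM.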

Compound 3, half-maximal inhibitory concentration: 55100 nM
The estimate for compound 3 lay 1.1-fold (0.04 log units) above the measured number; the measured number falls inside the stated range.
By their numbers in this assay, from the lowest: compounds 1, 3 and 2 (each within the scatter of the next).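

Working notes on the series: in this assay the step of a 1.5-fold lower number from compound 2 to compound 3 (0.17 log units; within the scatter) stands for methoxy in place of (ethylcarbamoyl)amino, and the step of a 1.2-fold higher number from compound 1 to compound 3 (0.08 log units; within the scatter) stands for methoxy in place of nitro. On this aromatic carbon, para to a large group, going from 6 heavy atoms and 2 hydrogen-bond donors to 2 heavy atoms and 0 hydrogen-bond donors therefore leaves the number within the scatter. Across nitro, methoxy and (ethylcarbamoyl)amino, the three compounds show no step beyond the scatter at this position, and no supporting data are available to account for that.

As far as these compounds go, whether an amine, a carboxylic acid or a longer chain on this carbon would give a step beyond the scatter remains open. So does the effect on the number of any change elsewhere on the shared core.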